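Solubility notes on the shared core, benzyl variations

A few compounds are considered here, and "the series" means these few. Any claim that something is new, unique, unknown or untested is made for them only; others in the source may bear on it.

Measured so far:
- compound 1, `Cc1noc(-c2nc(C)c3c(c2N)C(=O)N(Cc2ccc(-c4ccncc4)cc2)C3=O)n1`; in a physicochemical assay for solubility, using the shake flask method, in simulated intestinal fluid, measured as kinetic solubility, with a stated time of 2 h, at 25 degrees C, at pH 6.5 (on this read-out higher numbers stand for higher solubility and lower numbers for lower solubility), compound 1 gives < 5000 nM, a limit of the assay.
- compound 2, `Cc1noc(-c2nc(C)c3c(c2N)C(=O)N(Cc2ccc(-n4cccn4)cc2)C3=O)n1`; compound 2 gives < 5000 nM, a limit.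
- compound 3, `Cc1noc(-c2nc(C)c3c(c2N)C(=O)N(Cc2ccc(Br)cc2)C3=O)n1`; compound 3 gives < 5000 nM, a limit.

Compound 3 stands at a limit, not a number, and the other two values sit at the same place: the limit of < 5000 nM in this assay, at which 3 of the 3 values shown sit. The comparisons among the three, a step that the two limits leave unreadable from compound 1 to compound 2, a step that the two limits leave unreadable from compound 1 to compound 3 and a step that the two limits leave unreadable from compound 2 to compound 3, are therefore all unreadable; none shows a direction or a size.

Compound 4, `Cc1noc(-c2nc(C)c3c(c2N)C(=O)N(Cc2ccc(Cl)cn2)C3=O)n1`, is the next compound; its change from compound 3 is 5-chloropyridin-2-yl in place of 4-bromophenyl on a saturated chain carbon bound to an amide-type nitrogen in a ring. Among the measured compounds shown here, no measured step bears readably on this change, since every value shown is a limit. The expectation rests only on that: compound 4 is expected to sit near the same limit, with the step that the limit leaves unreadable from compound 3 to compound 4 estimated as small. Compound 4 is estimated at 3000 nM, within 800 nM to 9000 nM, with a fair chance that this assay again reports only a limit.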

Compound 4, solubility: < 5000 nM
Compound 4 was reported as a limit; the forecaster's own chance of this, stated with the estimate: 65%; the middle value does not contradict the limit.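

In this assay compound 4 gives < 5000 nM, a limit and not a number, so no comparison of compound 3 with compound 4 can be read: the limit of < 5000 nM in this assay, at which 4 of the 4 values shown sit.

On these data alone, the actual solubility of compound 1, compound 2, compound 3 and compound 4, and whether the changes among them shift it at all, stays open.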